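Cyano to methylcarbamoyl: a step expected within scatter

A few compounds are considered here, and "the series" means these few. Any claim that something is new, unique, unknown or untested is made for them only; others in the source may bear on it.

Measured compounds:
compound 1 `N#Cc1ccc(-c2ccc3c(O)cccc3c2)cc1`: 16%
compound 2 `CS(=O)(=O)Nc1cccc(-c2ccc3c(O)cccc3c2)c1`: 19%

In an assay for binding affinity to 17-beta-hydroxysteroid dehydrogenase type 1 (Homo sapiens), with a stated time of 20 min, tested at 1 uM (a higher number here means more inhibition at the concentration tested (going by the name of the read-out), a lower number less inhibition), compound 1 gives 16%, the smaller of the two numbers shown. Compound 2 gives 19%, and that gap lies within the usual scatter of such measurements, so the two cannot be told apart. Both numbers are low.

Compound 3 `CNC(=O)c1ccc(-c2ccc3c(O)cccc3c2)cc1` differs from compound 1 in one place: methylcarbamoyl in place of cyano on an aromatic carbon. Among the compounds with values here, no pair of measured compounds shows this exact change, so there is no measured step to lean on. The entering group carries a hydrogen-bond donor, and compound 2 also carries a donor on its outer ring, yet its value sits within the scatter of compound 1. The step of a number 4 percentage points higher from compound 1 to compound 3 (within the scatter) is therefore expected to be none beyond the scatter. Compound 3 is estimated to give 20%, with a range from 5% to 40%.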

Compound 3, a percentage reported as inhibition, at one concentration (the size of the read-out at that concentration, not a potency): < 10%
Compound 3 was reported as a limit; the forecaster's own chance of this, stated with the estimate: 0%; at least 10 percentage points between middle value and limit.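

In this assay, compound 3 gives < 10%, and that value is a limit of the assay, not a number. Within the data shown here, this is the first change made in one place on this outer ring, and it reads as a number at least 6 percentage points lower from compound 1 to compound 3 (that floor lies within the scatter), so methylcarbamoyl, with its hydrogen-bond donor, brings no sign of a gain over cyano at this position, para to a large group. The true size of the step stays unknown because the value for compound 3 is reported only as a limit: the limit of < 10% in this assay, at which 1 of the 3 values shown sits.

As far as these compounds go, whether an amine or a carboxylic acid at this same position would lift the inhibition remains open. So does whether a longer chain on the amide nitrogen would behave differently from the methyl group.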